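The compounds below may be only part of what the source reports. "The series", "measured", "known", "first", "only" and "open" are said of these compounds alone.

Measured compounds:
compound 1, `CS(=O)(=O)Nc1ccc(Cl)c2c1CCCC2c1c[nH]cn1`, < 10000 nM
compound 2, `CCS(=O)(=O)Nc1cc(C2CCCCC2)cc2c1CCCC2c1c[nH]cn1`, 891 nM
compound 3, `CS(=O)(=O)Nc1cccc2c1CCCCC2c1c[nH]cn1`, 10000 nM

In an assay on isolated protein (Cricetulus griseus) for binding affinity to Alpha-1B adrenergic receptor (Mesocricetus auratus), read by radioligand binding (on this read-out lower numbers stand for stronger inhibition and higher numbers for weaker inhibition), compound 2 gives 891 nM, the lowest of the two numbers reported. Compound 3, with 10000 nM, sits higher on the scale, a gap that is beyond the scatter of repeated measurements. Compound 1 is reported only as a limit, < 10000 nM, and not as a number; (the limit of < 10000 nM in this assay, at which 1 of the 3 values shown sits).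

The step now followed goes from compound 2 to compound 4, `CCS(=O)(=O)Nc1cccc2c1CCCC2c1c[nH]cn1`, which has not yet been measured. The change is hydrogen in place of cyclohexyl on an aromatic carbon. Among the measured compounds shown here, no pair of measured compounds differing in one place is available, so the size of this step rests on expectation alone. Since compound 3, which also carries hydrogen rather than cyclohexyl on that carbon, gives 10000 nM, a weaker number for compound 4 is expected, with the step of a 5.6-fold higher number from compound 2 to compound 4 (0.75 log units; beyond the scatter) beyond the scatter. Compound 4 is estimated at 5000 nM, within the range 1500 nM to 15000 nM.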

Compound 4, inhibition constant: 1320 nM
The estimate for compound 4 lay 3.8-fold (0.58 log units) above the measured number; measured number outside the range, below it.
By their numbers in this assay, from the lowest: compounds 2 and 4 (each within the scatter of the next); then compound 3.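

In this assay, hydrogen in place of cyclohexyl on the aromatic carbon, which is meta to the (ethylsulfonyl)amino group and para to a fused ring, comes to a 1.5-fold higher number from compound 2 to compound 4 (0.17 log units; within the scatter). Among the compounds shown here, this single-change comparison shows that, in this series, the cyclohexyl group at this position makes no readable difference to the number, something the earlier compounds could not show because none of them differed in one place only. Nothing in the data at hand accounts for this result.

On these data alone, whether an amine, a carboxylic acid or a methoxy group on this same aromatic carbon would also leave the number within the scatter remains open. Also open, as far as these compounds go, is what a longer chain in place of the ethyl on the sulfonyl group would do on the core of compound 4.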